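This account rests on a few compounds, and the source may have more. Where it says the series, first, only, none or still open, it means among the compounds named here.

Within the data shown here, in a functional assay on SW480 cells (Homo sapiens) for inhibition, read by luminescence and resazurin assay, with a stated time of 3 days (a lower number here means a stronger inhibitor, a higher number a weaker inhibitor), compound 1 `C=CCNc1nc(NCc2ccc(C(=O)Nc3ccc(F)cc3)cc2)c2ccccc2n1` gives 11000 nM, while compound 2 `CCCNc1nc(NCc2ccc(C(=O)Nc3ccc(F)cc3)cc2)c2ccccc2n1` gives 1600 nM, the lowest of the two numbers known. Among the measured compounds shown here, the only measured step, a 6.9-fold lower number from compound 1 to compound 2 (0.84 log units; beyond the scatter), sits at the same place as the change now considered. Compound 3 `CNc1nc(NCc2ccc(C(=O)Nc3ccc(F)cc3)cc2)c2ccccc2n1` differs from compound 2 by hydrogen in place of ethyl on a saturated chain carbon bound to a nitrogen on an aromatic ring, that is, propyl to methyl. That step is a different change at the same position, so it bears only loosely on this one; the shift in this assay is therefore uncertain. A moderately higher number is expected for compound 3, a 2.2-fold higher number from compound 2 to compound 3 (0.34 log units; beyond the scatter). Compound 3 is estimated at 3500 nM, within 1000 nM to 12000 nM.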

Compound 3, half-maximal inhibitory concentration: 4100 nM
For compound 3 the middle estimate is 1.2-fold (0.07 log units) below the measured one; measured number inside the range.
By their numbers in this assay, from the lowest: compound 2; then compound 3; then compound 1.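

In this assay, moving from propyl to methyl raises the number only modestly (a 2.6-fold higher number from compound 2 to compound 3 (0.41 log units; beyond the scatter)), and the methyl compound still beats the vinyl-bearing chain (a 2.7-fold lower number from compound 1 to compound 3 (0.43 log units; beyond the scatter)). Chain length alone therefore does not set the order at this position: the shorter methyl chain falls between two longer chains that differ only by vinyl versus ethyl. No measured evidence here explains this order. On these data alone, whether a longer chain such as butyl would lower the number further remains open, as does the effect of a hydroxyl group on the chain.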